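Azido in place of ((4-nitrophenyl)carbonyl)oxy: working notes

A few compounds are considered here, and "the series" means these few. Any claim that something is new, unique, unknown or untested is made for them only; others in the source may bear on it.

In a functional assay on A549 cells (Homo sapiens) for antiproliferative activity, read by MTT assay, with a stated time of 48 h (on this read-out higher numbers stand for weaker inhibition and lower numbers for stronger inhibition), compound 1 (`CC(C)=CCC[C@]1(C)/C=C/[C@@H](OC(=O)C=C(C)C)[C@](C)(O)/C=C/C(=O)/C(CN2CCCC2)=C\C1`) gives 180 nM, compound 2 (`CC(C)=CCC[C@]1(C)/C=C/[C@@H](OC(=O)C=C(C)C)[C@](C)(O)/C=C/C(=O)/C(CN2CCN(C)CC2)=C\C1`) gives 940 nM and compound 3 (`CC(C)=CCC[C@]1(C)/C=C/[C@@H](OC(=O)C=C(C)C)[C@](C)(O)/C=C/C(=O)/C(COC(=O)c2ccc([N+](=O)[O-])cc2)=C\C1`) gives 1310 nM. Compound 3 sits level with compound 2: the data show a 1.4-fold higher number from compound 2 to compound 3 (0.14 log units; within the scatter). Compound 1 stands apart from both, with a 5.2-fold higher number from compound 1 to compound 2 (0.72 log units; beyond the scatter) and a 7.3-fold higher number from compound 1 to compound 3 (0.86 log units; beyond the scatter).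

Compound 4 (`CC(C)=CCC[C@]1(C)/C=C/[C@@H](OC(=O)C=C(C)C)[C@](C)(O)/C=C/C(=O)/C(CN=[N+]=[N-])=C\C1`) carries the next change, azido in place of ((4-nitrophenyl)carbonyl)oxy on a saturated chain carbon bound to a double-bonded ring carbon. All three measured steps concern this same place, so all three bear on the change. Only the two involving compound 1 go beyond the scatter, and none involves azido, so the data give no direct read on this group.

Compound 1 shows that this place can carry a number well under that of compound 3, with a 7.3-fold higher number from compound 1 to compound 3 (0.86 log units; beyond the scatter). On that basis, a small move toward a lower number is expected in this assay, probably not clearly beyond the scatter. The estimated step is a 1.6-fold lower number from compound 3 to compound 4 (0.21 log units; within the scatter). Compound 4 is expected at 800 nM, with an estimated range of 250 nM to 2500 nM.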

Compound 4, half-maximal inhibitory concentration: 1720 nM
Beside the measured number, compound 4's estimate is 2.2-fold (0.33 log units) below it; measured number inside the range.
By their numbers in this assay, from the lowest: compound 1; then compounds 2, 3 and 4 (each within the scatter of the next).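

In this assay, azido on a saturated chain carbon bound to a double-bonded ring carbon reads level with ((4-nitrophenyl)carbonyl)oxy, with a 1.3-fold higher number from compound 3 to compound 4 (0.12 log units; within the scatter), and level with 4-methylpiperazin-1-yl, with a 1.8-fold higher number from compound 2 to compound 4 (0.26 log units; within the scatter). A group of 3 heavy atoms with no ring therefore cannot be told apart here from one of 12 heavy atoms with a six-membered aromatic ring, so the step from one to the other leaves the number within the scatter. Pyrrolidin-1-yl now stands apart from azido as well, with a 9.6-fold higher number from compound 1 to compound 4 (0.98 log units; beyond the scatter), leaving compound 1 alone among the four, and nothing measured on these compounds accounts for that gap.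

Going by these compounds, how piperidin-1-yl, morpholin-4-yl or dimethylamino would read at this place remains open, and with it whether the separation of compound 1 belongs to pyrrolidin-1-yl alone or extends to other amines, given that compound 2, which also carries a ring amine, reads with compounds 3 and 4. On these data alone, a primary amine or a carboxylic acid on the same carbon is equally open.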